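Adding Hydroxy to Compound 1, Which Showed Only a Limit

The compounds below may be only part of what the source reports. "The series", "measured", "known", "first", "only" and "open" are said of these compounds alone.

Compound 1 `COc1cc(NCc2ccccc2)cc(OC)c1OC` reaches no number in a functional assay on KYSE-450 cells (Homo sapiens) for inhibition, read by MTT assay, with a stated time of 48 h; a lower number here means a stronger inhibitor, a higher number a weaker inhibitor: the value > 80000 nM is a limit of the assay, as the limit of > 80000 nM in this assay, at which 1 of the 2 values shown sits, records. In this assay, among the measured compounds shown here, compound 2 `CCCCC(=O)N(Cc1ccc(OC)c(O)c1)c1cc(OC)c(OC)c(OC)c1` gives 300 nM, but no step between compound 1 and compound 2 is defined, so only the two values themselves stand. Compound 3 `COc1cc(NCc2cccc(O)c2)cc(OC)c1OC` differs from compound 1 by hydroxy in place of hydrogen on an aromatic carbon. For the measured compounds named here, no measured step covers this change, so the expected shift in this assay is small, probably within the scatter. Compound 3 is therefore expected near 70000 nM, between 20000 nM and 200000 nM, an estimated step of an at least 1.1-fold lower number from compound 1 to compound 3 (0.05 log units; that floor lies within the scatter).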

Compound 3, half-maximal inhibitory concentration: 71300 nM
Compound 3: middle estimate off by 1.0-fold (0.01 log units), on the low side; low and high end bracket the measured number.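

In this assay the change from phenyl to 3-hydroxyphenyl gives an at least 1.1-fold lower number from compound 1 to compound 3 (0.05 log units; that floor lies within the scatter) and so replaces a limit with a number. Among the compounds shown here, this is the first reading of hydroxy in place of hydrogen at this place, meta to a large group, on the shared core. Only a floor can be given for this step, because compound 1 stands at a limit: the limit of > 80000 nM in this assay, at which 1 of the 3 values shown sits.

The compounds shown leave open whether a methoxy group or an amine at this place would read differently from hydroxy.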